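The source may hold more compounds than are shown below. What is called first, only, known or untested is meant among the compounds shown, and "the series" means these compounds.

Two pyrazole-bearing compounds were measured in a functional assay (Cortical neurone cells, Rattus norvegicus, strain Sprague-Dawley) for cytotoxicity, read by XTT assay, tested at 1 uM, in the presence of a further agent that is not named here (a higher number here means a weaker effect of the compound at the concentration tested, a lower number a stronger effect), before the present step was taken. Compound 1 `Cn1nc(-c2ccccc2)cc1-c1ccc2[nH]ccc2c1` gives 87.9% in this assay. Compound 2 `COc1ccc(-c2cc(-c3ccccc3)n[nH]2)cc1` gives 80.9% in this assay. Compound 2 stands alongside compound 1 on these numbers: the gap between the two lies within the usual scatter of this assay, so neither can be set apart from the other, and both sit in the region where the compounds leave most of the cortical neurones unharmed at the concentration tested.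

Compound 3 `Clc1ccc(-c2cc(-c3ccccc3)n[nH]2)cc1` has not yet been measured. It differs from compound 2 in one place: chloro in place of methoxy on an aromatic carbon. Among the measured compounds shown here, no pair of measured compounds shows a step of this kind, so nothing in the data themselves points to a direction.

Given that compound 2 gives 80.9% and compound 1 gives 87.9%, the expected step in this assay from compound 2 to compound 3 is a number 2.1 percentage points higher from compound 2 to compound 3 (within the scatter), no larger than the scatter. The expected value for compound 3 in this assay is estimated at 83%, with a range from 70% to 96%.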

Compound 3, a percentage reported as activity, at one concentration (the size of the read-out at that concentration, not a potency): 74.1%
Beside the measured number, compound 3's estimate is 8.9 percentage points above it, and the stated range covers the measured number.
By their numbers in this assay, from the lowest: compounds 3, 2 and 1 (each within the scatter of the next, the first and the last beyond it).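

In this assay, among the compounds shown here, this is the first step that can be read at this position, on an aromatic carbon para to a large group, and it comes to a number 6.8 percentage points lower from compound 2 to compound 3 (within the scatter). The earlier compounds shown here offered no such pair, and this one shows that chloro in place of methoxy does not set compound 3 apart from compound 2 at the single concentration tested, even though the exchange replaces two heavy atoms and one hydrogen-bond acceptor with one heavy atom and no acceptor. Nothing measured on these compounds offers an explanation for this outcome.

The compounds shown leave open whether this position accepts groups of a different kind, since a single exchange between two small substituents cannot show how an amine, a carboxylic acid or a longer chain on the same aromatic carbon would read in this assay. They also leave open whether the same exchange would give a similar step on another core, such as that of compound 1, as this step has been read on the core of compound 2 alone.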